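The source may hold more compounds than are shown below. What is called first, only, known or untested is meant among the compounds shown, and "the series" means these compounds.

Working notes on the series. Compound 1 `O=C1/C(=C/c2ccccc2)CCC/C1=C\c1ccccc1Cl` has been measured in an assay on isolated protein for inhibition of Alpha glucosidase (Homo sapiens), with stated times of 5 min and 15 min, tested at 50 uM (a higher number here means more inhibition at the concentration tested (going by the name of the read-out), a lower number less inhibition), and gives 43%. Compound 3 `O=C1/C(=C/c2ccccc2)CCC/C1=C\c1cccc(Cl)c1Cl` gives 44% in this assay, and compound 2 `COc1cc(/C=C2\CCC/C(=C\c3ccccc3)C2=O)cc(OC)c1OC` gives 16.3%. Of these three numbers compound 1 stands second highest: its value and that of compound 3 lie within the scatter of each other, while compound 2 sits beyond the scatter below it. Within the data shown here, only one step between neighbours differing in a single place has been measured, a number 1 percentage points higher from compound 1 to compound 3 (within the scatter), a step within the scatter.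

Compound 4 `O=C1/C(=C/c2ccccc2)CCC/C1=C\c1ccccc1Br` is not yet measured. It differs from compound 1 in one place: bromo in place of chloro on an aromatic carbon. Among the measured compounds shown here, no measured step exchanges one halogen for another on the aromatic carbon. For the measured compounds named here, the only step that touches this ring, the chloro-for-hydrogen step from compound 1 to compound 3, stayed within the scatter, so no step beyond the scatter is expected here either. For compound 4 the change in this assay is therefore estimated at a number 1 percentage points higher from compound 1 to compound 4 (within the scatter). The estimate for compound 4 is 44%, with a range from 30% to 58%.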

Compound 4, a percentage reported as inhibition, at one concentration (the size of the read-out at that concentration, not a potency): 46.8%
Compound 4: the middle estimate sits 2.8 percentage points below what was measured, within the range that was stated.
By their numbers in this assay, from the lowest: compound 2; then compounds 1, 3 and 4 (each within the scatter of the next).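

Bromo in place of chloro on an aromatic carbon, ortho to a large group, gives a number 3.8 percentage points higher from compound 1 to compound 4 (within the scatter) in this assay, and this is the only exchange of one halogen for another among the compounds shown. The earlier step, a number 1 percentage points higher from compound 1 to compound 3 (within the scatter), added a second chloro to the ring while the original chloro stayed in place, whereas this step replaces the halogen at the position itself, and it also stays within the scatter. No evidence on hand bears on this result.

From the compounds shown here alone, it remains open whether this position would keep the same reading with something other than a halogen, such as an amine or a carboxylic acid. The compounds shown also leave open what plain hydrogen at this carbon would give against the same core.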